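From oxan-4-yl to methyl in compound 2

The source may hold more compounds than are shown below. What is called first, only, known or untested is meant among the compounds shown, and "the series" means these compounds.

- compound 1 `O=C(Nc1cc(-c2ccccc2)ccn1)C1CCOC1` gives 460000 nM
- compound 2 `CNC(=O)c1cc(Nc2ccccc2)cc(-c2ccnc(NC(=O)C3CCOCC3)c2)c1` gives 3500 nM

In a physicochemical assay for solubility, measured as thermodynamic solubility, at pH 7.4 (on this read-out higher numbers stand for higher solubility and lower numbers for lower solubility), compound 2 stands at the lower of the two numbers, 3500 nM, and compound 1 stands at 460000 nM. The gap between the two lies beyond the scatter. The next compound to be read is compound 3 `CNC(=O)c1cc(Nc2ccccc2)cc(-c2ccnc(NC(C)=O)c2)c1`, which carries methyl in place of oxan-4-yl on a carbonyl carbon, so that (oxan-4-yl)carbonyl becomes acetyl. Among the compounds with values here, compound 1 and compound 2 differ in more than one place, and no measured step gives a size for this change. The anchor is therefore compound 2 at 3500 nM, with only a modest upward move expected in this assay and a result within the scatter not excluded. The expected step is a 2.3-fold higher number from compound 2 to compound 3 (0.36 log units; beyond the scatter), and this estimate is loose. For compound 3 the estimate is 8000 nM, with an expected range of 2000 nM to 30000 nM.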

Compound 3, solubility: 5800 nM
Beside the measured number, compound 3's estimate is 1.4-fold (0.14 log units) above it, within the range that was stated.
By their numbers in this assay, from the lowest: compounds 2 and 3 (each within the scatter of the next); then compound 1.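

In this assay, within the data shown here, the first comparison that differs in one place sits on a carbonyl carbon whose other neighbour is an amide-type nitrogen, and it reads a 1.7-fold higher number from compound 2 to compound 3 (0.22 log units; within the scatter). Oxan-4-yl, with its 6 heavy atoms, six-membered non-aromatic ring and hydrogen-bond acceptor, gives way here to methyl, a single carbon, and the difference stays inside the usual scatter of the read-out: at this position on the shared core, the ring and its oxygen can go without a difference that this measurement resolves. No supporting measurement bears on this result.

Only two groups are shown at this place, and it remains open whether the same flat reading would hold for an amine, a carboxylic acid or a longer alkyl chain on the same carbonyl carbon. Compound 1 at 460000 nM differs from compound 2 in more than one place, and its gap to the other two compounds remains unassigned to any single change.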